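Side-Chain Swap on a Shared Core: Solubility Expectation

A few compounds are considered here, and "the series" means these few. Any claim that something is new, unique, unknown or untested is made for them only; others in the source may bear on it.

Compound 1 `O=C1O[C@@H](CN2CCCCC2)CN1c1ccc(-n2cc(-c3ccccn3)cn2)c(F)c1` — 219000 nM
Compound 2 `O=C1O[C@@H](Cn2ccnn2)CN1c1ccc(-n2cc(-c3ccccn3)cn2)c(F)c1` — 247000 nM
Compound 3 `O=C(NC[C@H]1CN(c2ccc(-n3cc(-c4ccccn4)cn3)c(F)c2)C(=O)O1)C(F)F` — 29900 nM

These three compounds share one core and have been measured in a physicochemical assay for solubility, read by HPLC, with a stated time of 24 h; on this read-out lower numbers stand for lower solubility and higher numbers for higher solubility. Compound 3 stands lowest of the three: the steps of a 7.3-fold lower number from compound 1 to compound 3 (0.86 log units; beyond the scatter) and an 8.3-fold lower number from compound 2 to compound 3 (0.92 log units; beyond the scatter) both lie beyond the scatter, whereas a 1.1-fold higher number from compound 1 to compound 2 (0.05 log units; within the scatter) lies within it. Compound 4 `CNC(=O)[C@H]1CN(c2ccc(-n3cc(-c4ccccn4)cn3)c(F)c2)C(=O)O1` differs from compound 3 in one place: methylcarbamoyl in place of (((difluoromethyl)carbonyl)amino)methyl on a saturated ring carbon. For the measured compounds named here, no measured step makes this exact change; the two steps ending at compound 3, a 7.3-fold lower number from compound 1 to compound 3 (0.86 log units; beyond the scatter) and an 8.3-fold lower number from compound 2 to compound 3 (0.92 log units; beyond the scatter), only show that altering the group on that chain can move the number well beyond the scatter in either direction, and the shorter side chain of compound 4 has no measured counterpart. The expected step is therefore modest and uncertain, in the upward direction: a 2.0-fold higher number from compound 3 to compound 4 (0.30 log units; within the scatter). Compound 4 is estimated at 60000 nM, with a range from 15000 nM to 250000 nM.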

Compound 4, solubility: 26200 nM
For compound 4 the middle estimate is 2.3-fold (0.36 log units) above the measured one; measured number inside the range.
By their numbers in this assay, from the lowest: compounds 4 and 3 (each within the scatter of the next); then compounds 1 and 2 (each within the scatter of the next).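

In this assay, a 1.1-fold lower number from compound 3 to compound 4 (0.06 log units; within the scatter) shows that on this saturated ring carbon, methylcarbamoyl with 4 heavy atoms gives a reading within the scatter of (((difluoromethyl)carbonyl)amino)methyl with 7 heavy atoms, though both groups count 1 hydrogen-bond donor and 1 hydrogen-bond acceptor. Both a 9.4-fold lower number from compound 2 to compound 4 (0.97 log units; beyond the scatter) and an 8.4-fold lower number from compound 1 to compound 4 (0.92 log units; beyond the scatter) lie beyond the scatter, so the low level of compound 3 recurs in compound 4, which carries no difluoromethyl group. Nothing available explains this result.

The compounds shown leave open how a carboxylic acid or a simple amine such as dimethylamino would read on this ring carbon. They also leave open whether a longer chain ending in the same methylcarbamoyl would stay at this low level.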